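The compounds below may be only part of what the source reports. "The series", "measured", "known", "first", "only" and "open" are said of these compounds alone.

Compound 1 `COC(=O)C(C)Nc1cc(NS(=O)(=O)/C=C/c2c(OC)cc(OC)cc2OC)ccc1OC` and compound 2 `COC(=O)C(C)(C)Nc1cc(NS(=O)(=O)/C=C/c2c(OC)cc(OC)cc2OC)ccc1OC` share a core, and compound 2 carries one change from compound 1, marked (methyl in place of hydrogen on a saturated chain carbon bound to a carbonyl carbon, a nitrogen on an aromatic ring and a saturated chain carbon). In a functional assay on K562 cells (Homo sapiens) for cytotoxicity, read by trypan blue exclusion, with a stated time of 96 h (on this read-out lower numbers stand for stronger inhibition and higher numbers for weaker inhibition), compound 1 gives 300 nM, and compound 2 gives 300 nM, so the step of no change at the digits printed from compound 1 to compound 2 (within the scatter). Compound 3 `COc1cc(OC)c(/C=C/S(=O)(=O)Nc2ccc(OC)c(NC(C)C(=O)O)c2)c(OC)c1` differs from compound 1 in its core by hydrogen in place of methyl on an oxygen next to a carbonyl group, a step of a 38-fold lower number from compound 1 to compound 3 (1.57 log units; beyond the scatter); in this assay compound 3 gives 8 nM. Against compound 2 the step reads a 38-fold lower number from compound 2 to compound 3 (1.57 log units; beyond the scatter). Compound 4 `COc1cc(OC)c(/C=C/S(=O)(=O)Nc2ccc(OC)c(NC(C)(C)C(=O)O)c2)c(OC)c1` is not yet measured and differs from compound 3 by methyl in place of hydrogen on a saturated chain carbon bound to a carbonyl carbon, a nitrogen on an aromatic ring and a saturated chain carbon, the same change that turned compound 1 into compound 2. Since that earlier step was no change at the digits printed from compound 1 to compound 2 (within the scatter), the step from compound 3 to compound 4 is expected to be no change at the digits printed from compound 3 to compound 4 (within the scatter). Compound 4 is therefore estimated at 8 nM, between 3 nM and 25 nM.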

Compound 4, half-maximal inhibitory concentration in the K562 assay: 5 nM
Compound 4: middle estimate off by 1.6-fold (0.20 log units), on the high side; low and high end bracket the measured number.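

In the K562 assay, compound 4 gives 5 nM; the added methyl gives a 1.6-fold lower number from compound 3 to compound 4 (0.20 log units; within the scatter), and it behaves on the core of compound 3 as it did on the core of compound 1: the same change on two cores in the K562 assay, no change at the digits printed (within the scatter) from compound 1 to compound 2 and a 1.6-fold lower number (0.20 log units; within the scatter) from compound 3 to compound 4, 1.6-fold (0.20 log units) apart, within the scatter of two such steps. The change from methyl ester to carboxylic acid also carries over, giving a 60-fold lower number from compound 2 to compound 4 (1.78 log units; beyond the scatter), while the listed replacement of the whole side chain gives a 60-fold lower number from compound 1 to compound 4 (1.78 log units; beyond the scatter): the same change on two cores in the K562 assay, a 38-fold lower number (1.57 log units; beyond the scatter) from compound 1 to compound 3 and a 60-fold lower number (1.78 log units; beyond the scatter) from compound 2 to compound 4, 1.6-fold (0.20 log units) apart, within the scatter of two such steps. Among the compounds shown here, these results rest on only two cores, so they do not show that either change would behave the same way on any other core. In a physicochemical assay for solubility (on this read-out lower numbers stand for lower solubility and higher numbers for higher solubility), compound 3 gives 10000 ug/mL, and compound 4 gives 10000 ug/mL. In the physicochemical assay the added methyl gives no change at the digits printed from compound 3 to compound 4 (within the scatter).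

As far as these compounds go, it remains open whether a longer chain, such as ethyl in place of the added methyl, would leave the number unchanged. From the compounds shown here alone, an amide in place of the carboxylic acid is equally open.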